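Pyrrolidin-1-yl for (tert-butyl)amino on the carbonyl carbon

The compounds below may be only part of what the source reports. "The series", "measured", "known", "first", "only" and "open" are said of these compounds alone.

In a functional assay on A549 cells (Homo sapiens) for inhibition, read by sulforhodamine B assay, with a stated time of 72 h (a higher number here means a weaker inhibitor, a lower number a stronger inhibitor), compound 1 `Nc1sc(-c2ccc(Cl)cc2)c(-c2ccc(Cl)cc2)c1C(=O)NC1CCCCC1` gives 2410 nM and compound 2 `CC1CCN(C(=O)c2c(N)sc(-c3ccc(Cl)cc3)c2-c2ccc(Cl)cc2)CC1` gives 1750 nM, with a 1.4-fold lower number from compound 1 to compound 2 (0.14 log units; within the scatter). Compound 3 `CC(C)(C)NC(=O)c1c(N)sc(-c2ccc(Cl)cc2)c1-c1ccc(Cl)cc1` gives 8850 nM, the highest number of the three and the weakest inhibitor so far.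

Compound 4 `Nc1sc(-c2ccc(Cl)cc2)c(-c2ccc(Cl)cc2)c1C(=O)N1CCCC1` differs from compound 3 by pyrrolidin-1-yl in place of (tert-butyl)amino on a carbonyl carbon, which amounts to pyrrolidin-1-yl in place of (tert-butyl)amino on a carbonyl carbon. Within the data shown here, the closest precedent is a 5.1-fold higher number from compound 2 to compound 3 (0.70 log units; beyond the scatter), where 4-methylpiperidin-1-yl gives way to (tert-butyl)amino at that same place. Read backwards, this modest step points to a lower number. The step of a 3.7-fold higher number from compound 1 to compound 3 (0.56 log units; beyond the scatter) is also modest and points the same way. Among the measured compounds shown here, no measured compound carries pyrrolidin-1-yl, so the size of the step remains uncertain. A step toward a stronger inhibitor is expected, slightly smaller than these precedents: the expected change is a 3.0-fold lower number from compound 3 to compound 4 (0.47 log units; beyond the scatter). Compound 4 is estimated at 3000 nM, with an expected range of 1200 nM to 7000 nM.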

Compound 4, half-maximal inhibitory concentration: 890 nM
The estimate for compound 4 lay 3.4-fold (0.53 log units) above the measured number, and the stated range ends above it.
By their numbers in this assay, from the lowest: compounds 4, 2 and 1 (each within the scatter of the next, the first and the last beyond it); then compound 3.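

At the carbonyl carbon, the change from (tert-butyl)amino to pyrrolidin-1-yl gives a 9.9-fold lower number from compound 3 to compound 4 (1.00 log units; beyond the scatter) in this assay even though both groups have the same heavy-atom composition, so what matters here is not simply how many atoms the group contains. Compound 4 gives a 2.0-fold lower number from compound 2 to compound 4 (0.29 log units; within the scatter) and so cannot be told apart from the 4-methylpiperidin-1-yl amide, while a 2.7-fold lower number from compound 1 to compound 4 (0.43 log units; beyond the scatter) places it apart from the cyclohexylamino amide, although compound 1 and compound 2 also lie within the scatter of each other. No measurement available here explains these differences.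

Closing the ring and losing the amide hydrogen happen together in this change, and the compounds shown cannot separate them. An open-chain diethylamino or dimethylamino group on the same carbonyl carbon would lack that hydrogen without carrying a ring, and morpholin-4-yl would add a ring oxygen.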